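Swapping a Dimethoxyphenyl for a Chlorohydroxyphenyl

The source may hold more compounds than are shown below. What is called first, only, known or untested is meant among the compounds shown, and "the series" means these compounds.

Of the compounds shown here, two sharing one core have been tested in a functional assay on HT-29 cells (Homo sapiens) for antiproliferative activity, read by MTT assay, with a stated time of 72 h; a lower number here means a stronger inhibitor, a higher number a weaker inhibitor. Compound 1 `COc1cc(/C=C2\CCC/C(=C\c3cccc(O)c3)C2=O)cc(OC)c1OC` carries a 3-hydroxyphenyl on a double-bonded chain carbon bound to a double-bonded ring carbon, and in this assay compound 1 gives 7600 nM. Compound 2 `COc1cccc(/C=C2\CCC/C(=C\c3cc(OC)c(OC)c(OC)c3)C2=O)c1OC` carries a 2,3-dimethoxyphenyl at that place instead, and compound 2 gives 3200 nM. The step between them is a 2.4-fold lower number from compound 1 to compound 2 (0.38 log units; beyond the scatter), so compound 2 has the lower number of the two and stands as the stronger inhibitor among these measured compounds.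

Compound 3 `COc1cc(/C=C2\CCC/C(=C\c3ccc(O)c(Cl)c3)C2=O)cc(OC)c1OC` is the one still to be measured. It differs from compound 2 as follows: 3-chloro-4-hydroxyphenyl in place of 2,3-dimethoxyphenyl on a double-bonded chain carbon bound to a double-bonded ring carbon.

Among the measured compounds shown here, only one measured step exists, a 2.4-fold lower number from compound 1 to compound 2 (0.38 log units; beyond the scatter), and it is the sole guide. For the measured compounds named here, it bears on this change in that compound 1 and compound 3 both carry a ring with a hydroxyl where compound 2 carries the 2,3-dimethoxyphenyl, while the chlorine of compound 3 has no measured counterpart. The expected step is a 1.6-fold higher number from compound 2 to compound 3 (0.19 log units; within the scatter), a modestly higher number, close in size to the measured one. For compound 3 the estimate in this assay is 5000 nM, with a range from 1500 nM to 15000 nM.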

Compound 3, half-maximal inhibitory concentration: 3400 nM
Beside the measured number, compound 3's estimate is 1.5-fold (0.17 log units) above it, and the stated range covers the measured number.
By their numbers in this assay, from the lowest: compounds 2 and 3 (each within the scatter of the next); then compound 1.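

In this assay, the place on the double-bonded chain carbon takes 3-chloro-4-hydroxyphenyl as readily as 2,3-dimethoxyphenyl (a 1.1-fold higher number from compound 2 to compound 3 (0.03 log units; within the scatter)), even though the entering group has fewer heavy atoms and brings a hydrogen-bond donor that the leaving group lacks. A hydroxyl on this ring therefore does not by itself tie a compound to the higher number seen for compound 1, since exchanging 3-hydroxyphenyl for 3-chloro-4-hydroxyphenyl gives a modest step beyond the scatter (a 2.2-fold lower number from compound 1 to compound 3 (0.35 log units; beyond the scatter)). No measurement is available that explains either step.

The compounds shown cannot separate the contribution of the chlorine from that of the hydroxyl's placement, as 3-hydroxyphenyl and 3-chloro-4-hydroxyphenyl differ in both, so a hydroxyphenyl without chlorine and a chlorophenyl without hydroxyl would be the informative neighbours. On these data alone, it also remains open whether this place would tolerate a ring carrying an amine or a carboxylic acid, and whether the near-equality of compound 2 and compound 3 holds in any cells other than these.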